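Methoxy for nitro in a weakly cytotoxic series

This account rests on a few compounds, and the source may have more. Where it says the series, first, only, none or still open, it means among the compounds named here.

In a functional assay on K-562R cells (Homo sapiens) for cytotoxicity, read by MTT assay, with a stated time of 48 h (a lower number here means a stronger inhibitor, a higher number a weaker inhibitor), compound 1 (`COc1ccc(-c2c[nH]c(=O)n2-c2cc(OC)c(OC)c(OC)c2)cc1`) reads > 50000 nM as a limit of the assay and not a number. Going by the values given here, compound 2 (`COc1cc(-n2c(-c3ccc([N+](=O)[O-])cc3)cn(C(C)=O)c2=O)cc(OC)c1OC`) gives 49600 nM as the only actual number so far. The change to compound 3 (`COc1ccc(-c2cn(C(C)=O)c(=O)n2-c2cc(OC)c(OC)c(OC)c2)cc1`) is methoxy in place of nitro on an aromatic carbon, para to a large group (methoxy in place of nitro on an aromatic carbon). Among the compounds with values here, no measured step yet informs this change. The step expected in this assay is a 2.5-fold lower number from compound 2 to compound 3 (0.39 log units; beyond the scatter) towards stronger inhibition, a tentative expectation. Compound 3 is estimated at 20000 nM (range 3000 nM to 50000 nM).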

Compound 3, half-maximal inhibitory concentration: 9500 nM
Estimate against measurement, compound 3: 2.1-fold (0.32 log units) above, and the stated range covers the measured number.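

In this assay, 4-nitrophenyl to 4-methoxyphenyl gives a 5.2-fold lower number from compound 2 to compound 3 (0.72 log units; beyond the scatter), so this position on the aromatic ring responds to the change of group. With the methoxy kept, acetyl in place of hydrogen on an aromatic nitrogen gives an at least 5.2-fold lower number from compound 1 to compound 3 (0.72 log units; beyond the scatter). Compound 1 stands at a limit of the assay and not a number, so that second step is only a bound: the limit of > 50000 nM in this assay, at which 1 of the 3 values shown sits.

The compounds shown leave open how an amine or an ethoxy group on the same aromatic carbon would read. From the compounds shown here alone, a longer acyl chain on that nitrogen also remains open.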